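A ring swap and what compound 4 may show

The source may report more compounds than this note shows. Statements on the series, on what has been measured and on what is new or still open speak of the compounds shown alone.

For the measured compounds named here, in an ADME assay on Vero cells (Chlorocebus sabaeus) for cytotoxicity, read by MTT assay, with a stated time of 72 h (on this read-out lower numbers stand for higher toxicity in this test and higher numbers for lower toxicity in this test), compound 2 (`COc1ccc(/C=C(\C)C(=O)/C=C/c2cccc(Br)c2)cc1`) gives 153000 nM, the highest of the three numbers so far and so the lowest toxicity in this test. Compound 1 (`CC/C(=C\c1ccc(Cl)cc1)C(=O)/C=C/c1ccc([N+](=O)[O-])cc1`) gives 36000 nM, and compound 3 (`CC/C(=C\c1ccc(Cl)cc1)C(=O)/C=C/c1ccc(C=O)cc1`) gives 46900 nM. Compound 4 (`COc1ccc(/C=C(\C)C(=O)/C=C/c2ccccc2F)cc1`) carries 2-fluorophenyl in place of 3-bromophenyl on a double-bonded chain carbon bound to a double-bonded chain carbon.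

Going by the values given here, no measured pair shows this swap directly. Among the compounds with values here, the nearest guide is the only single-place change measured, a 1.3-fold higher number from compound 1 to compound 3 (0.11 log units; within the scatter), and it stays within the scatter. It suggests that one group exchange need not move the number much, though it involves different groups. Compound 1 at 36000 nM and compound 3 at 46900 nM both lie under compound 2, so a slight fall looks likelier than a rise. The expected change is a 1.3-fold lower number from compound 2 to compound 4 (0.11 log units; within the scatter), a small step that may not exceed the scatter. For compound 4 the estimated value is 120000 nM, with an expected range from 45000 nM to 300000 nM.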

Compound 4, half-maximal cytotoxic concentration: 81200 nM
Beside the measured number, compound 4's estimate is 1.5-fold (0.17 log units) above it; low and high end bracket the measured number.
By their numbers in this assay, from the lowest: compounds 1, 3, 4 and 2 (each within the scatter of the next, the first and the last beyond it).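

In this assay, 2-fluorophenyl in place of 3-bromophenyl on a double-bonded chain carbon bound to a double-bonded chain carbon gives a 1.9-fold lower number from compound 2 to compound 4 (0.28 log units; within the scatter), the first step measured at this place, and it does not clearly separate the two compounds. The swap changes two things at once, the halogen (bromine to fluorine) and where it sits on the ring, so this single step cannot assign any share of the difference to either one. Nothing available here explains the result.

A 3-fluorophenyl or a 2-bromophenyl group at this place would pull those two changes apart, and an unsubstituted phenyl would show what the halogen adds at all. As far as these compounds go, how a ring carrying an amine or a carboxylic acid would behave at this place also remains open.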